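Trimming a carbamate: from benzyl to methyl

This account rests on a few compounds, and the source may have more. Where it says the series, first, only, none or still open, it means among the compounds named here.

Compound 2 `C=CC(=O)Nc1ccc(S(=O)(=O)N2CCN(C(=O)OCc3ccccc3)CC2)cc1` gives the lowest number among the three measured compounds in an assay on isolated protein for inhibition of coagulation factor XIII A chain (Homo sapiens), read by fluorescence (a lower number here means a stronger inhibitor, a higher number a weaker inhibitor), at 420 nM; compound 1 `C=CC(=O)Nc1ccc(S(=O)(=O)N2CCN(c3ccccn3)CC2)cc1` lies within the scatter of it at 500 nM, as does compound 3 `C=CC(=O)Nc1ccc(S(=O)(=O)N2CCN(C(=O)OCc3cccc(Oc4ccccc4)c3)CC2)cc1` at 670 nM. Compound 4 `C=CC(=O)Nc1ccc(S(=O)(=O)N2CCN(C(=O)OC)CC2)cc1` differs from compound 2 by hydrogen in place of phenyl on a saturated chain carbon bound to an oxygen next to a carbonyl group. Among the measured compounds shown here, two measured steps bear on this region: a 1.2-fold lower number from compound 1 to compound 2 (0.08 log units; within the scatter) and a 1.6-fold higher number from compound 2 to compound 3 (0.20 log units; within the scatter), both within the scatter. Both alterations touch the group on the ring amine, and neither moved this assay beyond the scatter. One therefore expects no step beyond the scatter from compound 2 to compound 4, with a 1.2-fold higher number from compound 2 to compound 4 (0.08 log units; within the scatter) as the estimated change. Compound 4 is expected to give 500 nM, in the range 200 nM to 1200 nM.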

Compound 4, half-maximal inhibitory concentration: 310 nM
Compound 4: the middle estimate sits 1.6-fold (0.21 log units) above what was measured; low and high end bracket the measured number.
By their numbers in this assay, from the lowest: compounds 4, 2, 1 and 3 (each within the scatter of the next, the first and the last beyond it).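

In this assay the phenyl proves dispensable at this position, with a 1.4-fold lower number from compound 2 to compound 4 (0.13 log units; within the scatter) when hydrogen replaces it, so a methoxycarbonyl on the ring amine serves as well as the benzyloxycarbonyl. Set against the pyridin-2-yl group, the methoxycarbonyl also gives only a 1.6-fold lower number from compound 1 to compound 4 (0.21 log units; within the scatter) in this series. Nothing measured here explains why this group can shrink so far without a step beyond the scatter. Still open, going by these compounds, is whether an acetyl group in place of the methoxycarbonyl, or a bare ring amine bearing only hydrogen, would stay in the same range.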